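Methoxy on the benzoyl ring of a bromochalcone

The compounds below may be only part of what the source reports. "The series", "measured", "known", "first", "only" and "open" are said of these compounds alone.

Compound 1 `COc1cc(Br)cc(/C=C/C(=O)c2ccccc2)c1O` gives 28.1% in a functional assay on MCF7 cells (Homo sapiens) for antiproliferative activity, read by sulforhodamine B assay, with a stated time of 72 h, tested at 30 uM (on this read-out lower numbers stand for a stronger effect and higher numbers for a weaker effect at the one concentration tested), and this is the highest of the two numbers in hand; compound 2 `COc1cc(Br)cc(/C=C/C(=O)c2ccc(Cl)cc2)c1O` gives 28%. The step of a number 0.1 percentage points lower from compound 1 to compound 2 (within the scatter) is the only one that touches the same ring as the change now considered. Compound 3 `COc1cccc(C(=O)/C=C/c2cc(Br)cc(OC)c2O)c1` differs from compound 1 by methoxy in place of hydrogen on an aromatic carbon. Since the one comparable substitution on that ring left the read-out unchanged, compound 3 is expected to show a step of a number 1.9 percentage points higher from compound 1 to compound 3 (within the scatter), none beyond the scatter. Compound 3 is estimated at 30%, between 15% and 50%.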

Compound 3, a percentage reported as activity, at one concentration (the size of the read-out at that concentration, not a potency): 63.1%
Estimate against measurement, compound 3: 33.1 percentage points below, and the stated range ends below it.
By their numbers in this assay, from the lowest: compounds 2 and 1 (each within the scatter of the next); then compound 3.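

In this assay, methoxy in place of hydrogen, meta to a large group, gives a number 35 percentage points higher from compound 1 to compound 3 (beyond the scatter) and so a clearly weaker effect at the one concentration tested. The chloro step had left the read-out within the scatter, but this step shows that the ring does not accept every substituent without loss. Nothing available here accounts for the step.

Going by these compounds, it remains open whether the loss belongs to methoxy itself or to this place on the ring. An amine or a carboxylic acid on the same carbon, or methoxy on another carbon of that ring, could separate the two.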